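The source may report more compounds than this note shows. Statements on the series, on what has been measured and on what is new or still open speak of the compounds shown alone.

Values in a functional assay on MCF7 cells (Homo sapiens) for antiproliferative activity, read by sulforhodamine B assay, with a stated time of 48 h; a higher number here means a weaker inhibitor, a lower number a stronger inhibitor:
compound 1 `COc1cccc(OS(=O)(=O)c2ccc(N3CCN(C)C3=O)cc2)c1`: 3000 nM
compound 2 `CN1CCN(c2ccc(S(=O)(=O)Oc3cccc([N+](=O)[O-])c3)cc2)C1=O`: > 100000 nM
compound 3 `COc1cc(OC)cc(OS(=O)(=O)c2ccc(N3CCN(C)C3=O)cc2)c1`: 230 nM

The entry for compound 2 is a limit, not a number. Of the two true numbers, compound 1 holds the higher. Compound 4 `COc1ccc(OS(=O)(=O)c2ccc(N3CCN(C)C3=O)cc2)cc1` has the same atoms as compound 1, joined differently: 4-methoxyphenyl in place of 3-methoxyphenyl on an oxygen. Among the compounds with values here, two measured steps bear on this methoxyphenyl group, and both are large: a 13-fold lower number from compound 1 to compound 3 (1.12 log units; beyond the scatter), adding a methoxy, and an at least 33-fold higher number from compound 1 to compound 2 (1.52 log units; beyond the scatter), with nitro in place of methoxy. Neither exchanges one methoxyphenyl for the other, so they give no firm direction, and the expected range stays wide. The estimated step in this assay is a 1.3-fold higher number from compound 1 to compound 4 (0.12 log units; within the scatter), with no clear shift expected beyond the scatter. For compound 4 the estimated value is 4000 nM, with an expected range from 800 nM to 20000 nM.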

Compound 4, half-maximal inhibitory concentration: 95000 nM
The estimate for compound 4 lay 24-fold (1.38 log units) below the measured number; the whole stated range lies below it.
By their numbers in this assay, from the lowest: compound 3; then compound 1; then compound 4. At a limit, above all of these: compound 2.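

In this assay, the step from 3-methoxyphenyl to 4-methoxyphenyl on an oxygen is a 32-fold higher number from compound 1 to compound 4 (1.50 log units; beyond the scatter). The earlier steps shown here each added or exchanged a group, whereas this one gains and loses no atom, so placement of the methoxy alone carries a large change. Compound 2 remains a limit, not a number: the limit of > 100000 nM in this assay, at which 1 of the 4 values shown sits.

Still open, on these data alone, is whether a hydroxyl or an amine in place of the methoxy would follow the same dependence on placement. Also open, as far as these compounds go, is how a second methoxy would act on the 4-methoxyphenyl group of compound 4.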